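The source may hold more compounds than are shown below. What is called first, only, known or untested is meant among the compounds shown, and "the series" means these compounds.

Measured so far in an ADME assay on a cell-free system (plasma, Homo sapiens) for metabolic stability; on this read-out lower numbers stand for a shorter-lived compound and higher numbers for a longer-lived compound:
- compound 1 `C=C1C(=O)O[C@H]2[C@H]1CC/C(COC(=O)N1CCC(F)(F)CC1)=C\CC[C@@]1(C)O[C@@H]21`: 8 h
- compound 2 `C=C1C(=O)O[C@H]2[C@H]1CC/C(COC(=O)NCCN1CCCC1)=C\CC[C@@]1(C)O[C@@H]21`: 1.67 h

Compound 2, at 1.67 h, holds the lower of the two numbers, and its gap to compound 1 lies beyond the scatter. Compound 3 `C=C1C(=O)O[C@H]2[C@H]1CC/C(COC(=O)Nc1n[nH]c(SC)n1)=C\CC[C@@]1(C)O[C@@H]21` has yet to be measured in this assay. The change from compound 2 is 5-(methylsulfanyl)-1H-1,2,4-triazol-3-yl in place of 2-(pyrrolidin-1-yl)ethyl on an amide-type nitrogen.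

Among the measured compounds shown here, only one measured step bears on this: a 4.8-fold lower number from compound 1 to compound 2 (0.68 log units; beyond the scatter). That step is modest, and it shows that the number can move with what is attached to the carbonyl carbon. Two compounds establish no trend, and neither carries an aromatic ring in this place, so the direction is uncertain. With compound 1 at 8 h as the only higher reference, a modest rise is expected, smaller than the measured step. The estimated step is a 2.1-fold higher number from compound 2 to compound 3 (0.32 log units; beyond the scatter). Compound 3 is expected at 3.5 h, with an estimated range of 1.2 h to 10 h.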

Compound 3, half-life: 1.67 h
Estimate against measurement, compound 3: 2.1-fold (0.32 log units) above; the measured number falls inside the stated range.
By their numbers in this assay, from the lowest: compounds 2 and 3 (each within the scatter of the next); then compound 1.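

Notes on the group on the carbamate nitrogen, read in this assay: the step from 2-(pyrrolidin-1-yl)ethyl to 5-(methylsulfanyl)-1H-1,2,4-triazol-3-yl is no change at the digits printed from compound 2 to compound 3 (within the scatter) even though the two groups share a heavy-atom count and differ in ring type and hetero atoms. Replacing 4,4-difluoropiperidin-1-yl on the carbonyl carbon with the triazolylamino group gives a 4.8-fold lower number from compound 1 to compound 3 (0.68 log units; beyond the scatter), the same size as a 4.8-fold lower number from compound 1 to compound 2 (0.68 log units; beyond the scatter), so among these three compounds the two that keep the amide hydrogen stand together and compound 1, whose nitrogen lies in a ring, stands apart, with no listed compound against this. Nothing at hand gives a cause for this grouping.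

From the compounds shown here alone, it stays open whether a methyl on the amide-type nitrogen, or an unfluorinated piperidin-1-yl on the carbonyl carbon, would read with compound 1 or with compound 2 and compound 3. The half-life alone also leaves open which part of the molecule is lost, the carbamate or the shared core.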